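Cytotoxicity limits across the series and one untested analogue

A few compounds are considered here, and "the series" means these few. Any claim that something is new, unique, unknown or untested is made for them only; others in the source may bear on it.

In an ADME assay on HEp-2 cells (Homo sapiens) for cytotoxicity, with a stated time of 4 days (on this read-out higher numbers stand for lower toxicity in this test and lower numbers for higher toxicity in this test), compound 2 `CS(=O)(=O)c1nn(Cc2nc3cc(Cl)ccc3n2CCCCO)c2cnccc12` gives > 100000 nM, which is a limit of the assay rather than a number. Compound 1 `CS(=O)(=O)CCn1c(Cn2cc(S(C)(=O)=O)c3ccccc32)nc2ccccc21` likewise gives > 100000 nM, again only a limit. Both results therefore sit at the limit of > 100000 nM in this assay, at which 2 of the 2 values shown sit, and no order between the two compounds can be read from them. Compound 3 `CS(=O)(=O)c1nn(Cc2nc3cc(Cl)ccc3n2CCC(O)C(F)(F)F)c2cnccc12` has not yet been measured; it differs from compound 2 by 2,2,2-trifluoro-1-hydroxyethyl in place of 2-hydroxyethyl on a saturated chain carbon, two bonds along the chain from an aromatic nitrogen. Among the compounds with values here, no step between measured compounds is available, so nothing measured shows how a change of this kind moves the read-out. Compound 2 stands only at the limit > 100000 nM. On that basis the step that the limit leaves unreadable from compound 2 to compound 3 is expected to be none beyond the scatter, and a limit is again the likely outcome. For compound 3 the estimate is 150000 nM, within a range of 50000 nM to 500000 nM.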

Compound 3, half-maximal cytotoxic concentration: > 100000 nM
Compound 3 ended at the assay's limit; the forecaster's own chance of this, stated with the estimate: 85%; the middle value lies beyond the limit too.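

In this assay no step can be read from compound 2 to compound 3, since both results are limits and not numbers: the limit of > 100000 nM in this assay, at which 3 of the 3 values shown sit.
The compounds shown leave open how far each lies past that limit, and whether 2,2,2-trifluoro-1-hydroxyethyl in place of 2-hydroxyethyl moves the read-out at all.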